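Removing the nitro group: what does the bare phenyl ketone do?

The compounds below may be only part of what the source reports. "The series", "measured", "known", "first", "only" and "open" are said of these compounds alone.

Measured so far:
compound 1, `CCOc1ccc(C(=O)CSc2nc3ccccc3[nH]2)cc1`: 55.2%
compound 2, `O=C(CSc1nc2ccccc2[nH]1)c1ccc([N+](=O)[O-])cc1`: "not active" (no number reported)

In a functional assay on HT-29 cells (Homo sapiens) for inhibition, read by flow cytometry, tested at 10 uM (a lower number here means less inhibition, a higher number more inhibition at the concentration tested (going by the name of the read-out)), compound 1 gives 55.2%. In this assay compound 2 is reported as "not active" (no number reported), so no single number stands for compound 2; it is only known to sit below whatever would have been reported as a value, and it cannot be ranked against compound 1 by a figure.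

Compound 3, `O=C(CSc1nc2ccccc2[nH]1)c1ccccc1`, is the next point. Compared with compound 2 the change is hydrogen in place of nitro on an aromatic carbon. Among the measured compounds shown here, no step between two measured compounds is available for this change, so the direction is expected only from the qualitative report for compound 2 and the value of compound 1: in this assay an increase over compound 2 is expected, probably beyond the usual scatter, but its size is open. Compound 3 is estimated at 30%, in the range 5% to 60%.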

Compound 3, a percentage reported as inhibition, at one concentration (the size of the read-out at that concentration, not a potency): "not active" (no number reported)
The entry for compound 3 holds no number, so the estimate cannot be set against anything.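

In this assay compound 2 and compound 3 are both reported as not active, without a number, so no step can be read between them. No evidence shown bears on this result. The compounds shown leave open whether compound 2 and compound 3 differ at all in this assay.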